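The compounds below may be only part of what the source reports. "The series", "measured", "known", "first", "only" and "open" are said of these compounds alone.

Measured compounds in a functional assay on PC-3 cells (Homo sapiens) for antiproliferative activity, read by MTT assay, with a stated time of 48 h; a lower number here means a stronger inhibitor, a higher number a weaker inhibitor:
compound 1 `N#CC1=C(N)Oc2cc3oc(-c4ccccc4)cc(=O)c3c(O)c2C12C(=O)N(c1ccccc1)c1ccccc12`: > 50000 nM, a limit of the assay rather than a number
compound 2 `CCN1C(=O)C2(C(C#N)=C(N)Oc3cc4oc(-c5ccccc5)cc(=O)c4c(O)c32)c2cc(C)ccc21`: > 50000 nM, likewise only a limit of the assay

Compound 1 stands at the boundary of this assay, and only a limit is known for it. Compound 2 stands at the same boundary. Both values sit on one line, (the limit of > 50000 nM in this assay, at which 2 of the 2 values shown sit), so no size or direction of a step between the two measured compounds can be read from them.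

Compound 3 `N#CC1=C(N)Oc2cc3oc(-c4ccccc4)cc(=O)c3c(O)c2C12C(=O)Nc1ccccc12` is not yet measured. It differs from compound 1 by hydrogen in place of phenyl on an amide-type nitrogen in a ring. Among the measured compounds shown here, with no measured step known, the expected step is a step that the limit leaves unreadable from compound 1 to compound 3, which amounts to none beyond the scatter. Compound 3 is therefore expected near 60000 nM, in the range 20000 nM to 200000 nM, and this assay may again report only a limit for it.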

Compound 3, half-maximal inhibitory concentration: > 50000 nM
Compound 3: a limit, no number; the forecaster's own chance of this, stated with the estimate: 75%; the middle value is on the limit's open side.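

No step can be read from compound 1 to compound 3 in this assay, as each value is a limit and not a number: the limit of > 50000 nM in this assay, at which 3 of the 3 values shown sit.

The compounds shown leave open whether phenyl or hydrogen on the amide-type nitrogen in a ring makes any difference, and which change to the shared core would give a number in this assay.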